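Propyl to butyl carbamate on a selenocyanate aryl core

A few compounds are considered here, and "the series" means these few. Any claim that something is new, unique, unknown or untested is made for them only; others in the source may bear on it.

Measured compounds:
compound 1 `COc1ccc(OC(=O)Nc2ccc([Se]C#N)cc2)cc1` gives 41500 nM
compound 2 `CCCOC(=O)Nc1ccc([Se]C#N)cc1` gives 51900 nM

Two carbamates were tested in a functional assay on HT-29 cells (Homo sapiens) for cytotoxicity, read by MTT assay, with a stated time of 72 h; on this read-out higher numbers stand for weaker inhibition of growth and lower numbers for stronger inhibition of growth. Compound 1 gives 41500 nM in this assay, and compound 2 gives 51900 nM. Compound 2 thus stands beside compound 1; the gap between them lies within the usual scatter of repeated measurements, so the two numbers tell no order.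

Compound 3 `CCCCOC(=O)Nc1ccc([Se]C#N)cc1` has not yet been measured in this assay. It differs from compound 2 by methyl in place of hydrogen on a saturated chain carbon, three bonds along the chain from an oxygen next to a carbonyl group. Among the measured compounds shown here, no step between measured compounds mirrors this change, so the data give no direct guide. Given that compound 2 gives 51900 nM with a chain already of some length, the lengthening is expected to move the number little, with no step beyond the scatter in either direction. The expected step from compound 2 to compound 3 is a 1.2-fold lower number from compound 2 to compound 3 (0.06 log units; within the scatter). Compound 3 is therefore estimated at 45000 nM, with a range from 20000 nM to 100000 nM.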

Compound 3, concentration for total growth inhibition: 31300 nM
Beside the measured number, compound 3's estimate is 1.4-fold (0.16 log units) above it; the measured number falls inside the stated range.
By their numbers in this assay, from the lowest: compounds 3, 1 and 2 (each within the scatter of the next).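

In this assay, the lengthening of the carbamate chain from propyl to butyl gives a 1.7-fold lower number from compound 2 to compound 3 (0.22 log units; within the scatter). Among the compounds shown here, this is the first step read at this position, and it shows that methyl in place of hydrogen on this saturated chain carbon produces no change that can be told apart from repeated measurement. Nothing measured here bears on why the two numbers lie so close.

A single step cannot show whether the number would stay within the scatter along a longer chain, such as pentyl or hexyl, or with a shorter ethyl chain. It also leaves open whether a hydroxyl group or an amine in place of the added methyl would give a step beyond the scatter.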